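Shortening the amide chain of compound 1

The source may hold more compounds than are shown below. What is called first, only, known or untested is meant among the compounds shown, and "the series" means these compounds.

Compound 1 `CC(C)CCC(=O)Nc1ccn([C@H]2CC[C@H](O)[C@@H](C)O2)c(=O)n1` carries an isopentylcarbonyl amide on the shared core. In a functional assay on HCT-116 cells (Homo sapiens) for cytotoxicity, read by sulforhodamine B assay, with a stated time of 24 h (on this read-out lower numbers stand for stronger inhibition and higher numbers for weaker inhibition), compound 1 gives > 20000 nM, which is a limit of the assay rather than a measured number (the limit of > 20000 nM in this assay, at which 1 of the 3 values shown sits). Two larger relatives have been measured as well: compound 2 `CC(C)CC(=O)Nc1ccn([C@H]2CC[C@H](O[C@H]3O[C@H](C)[C@@H](N(C)C)[C@H](O)[C@H]3O)[C@@H](C)O2)c(=O)n1` gives 2140 nM in this assay, and compound 3 `CC(C)/C=C/C(=O)Nc1ccn([C@H]2CC[C@H](O[C@H]3O[C@H](C)[C@@H](N(C)C)[C@H](O)[C@H]3O)[C@@H](C)O2)c(=O)n1` gives 780 nM. Going by the values given here, the one measured step between them, a 2.7-fold lower number from compound 2 to compound 3 (0.44 log units; beyond the scatter), alters the acyl group while leaving the rest untouched.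

Compound 4 `CCC(=O)Nc1ccn([C@H]2CC[C@H](O)[C@@H](C)O2)c(=O)n1` differs from compound 1 by hydrogen in place of isopropyl on a saturated chain carbon, two bonds along the chain from a carbonyl carbon. Among the compounds with values here, no measured step removes part of the chain in this way; the only acyl change on record is the modest one on the larger pair, which offers little guidance for a compound that starts at the assay limit. Compound 1 stands at that limit (the limit of > 20000 nM in this assay, at which 1 of the 3 values shown sits), and compound 4 is therefore expected to remain there as well. The expected step from the smaller amide is a step that the limit leaves unreadable from compound 1 to compound 4, judged to lie within the scatter. The estimate for compound 4 is 25000 nM, with a range from 10000 nM to 60000 nM, and the assay is expected most likely to report only a limit again.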

Compound 4, half-maximal inhibitory concentration: > 20000 nM
Compound 4 was reported as a limit; the forecaster's own chance of this, stated with the estimate: 80%; the middle value is on the limit's open side.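

Compound 1 and compound 4 are both reported only as limits, so no size can be read for the change from isopentylcarbonyl to propanoyl: the limit of > 20000 nM in this assay, at which 2 of the 4 values shown sit.

The compounds shown leave open how these two amide chains would compare on the larger relatives, where the assay gives numbers rather than limits.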